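The compounds below may be only part of what the source reports. "The series", "measured", "known", "first", "only" and "open" are said of these compounds alone.

Measured so far in a functional assay on MGC-803 cells (Homo sapiens) for inhibition, read by MTT assay, with a stated time of 72 h; a lower number here means a stronger inhibitor, a higher number a weaker inhibitor: compound 1 `Cc1cc(Nc2cc(-c3ccccc3)[nH]n2)n2nc(SCc3ccc([N+](=O)[O-])cc3)nc2n1` at 4250 nM, compound 2 `Cc1cc(Nc2cc(-c3ccccc3)[nH]n2)n2nc(SCc3nc4ccccc4[nH]3)nc2n1` at 1790 nM, compound 3 `Cc1ccc(CSc2nc3nc(C)cc(Nc4cc(-c5ccccc5)[nH]n4)n3n2)cc1` at 6960 nM.

Compound 1 holds the second highest of the three numbers. Its nearest neighbour is compound 3, a 1.6-fold higher number from compound 1 to compound 3 (0.21 log units; within the scatter); its furthest is compound 2, a 2.4-fold lower number from compound 1 to compound 2 (0.38 log units; beyond the scatter).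

Compound 4 `COc1ccc(CSc2nc3nc(C)cc(Nc4cc(-c5ccccc5)[nH]n4)n3n2)cc1` differs from compound 1 as follows: methoxy in place of nitro on an aromatic carbon. For the measured compounds named here, the only measured step that bears on this change is the one from compound 1 to compound 3, where methyl replaced nitro on the same aromatic carbon, a 1.6-fold higher number from compound 1 to compound 3 (0.21 log units; within the scatter). The step from compound 2 to compound 3, a 3.9-fold higher number from compound 2 to compound 3 (0.59 log units; beyond the scatter), concerns the group on the sulfur-bound carbon and does not inform the exchange of a substituent on the ring. A small shift toward a higher number, not beyond the scatter, is therefore expected for compound 4.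

Compound 4 is estimated at 5500 nM, with a range from 2500 nM to 12000 nM. The expected step is a 1.3-fold higher number from compound 1 to compound 4 (0.11 log units; within the scatter).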

Compound 4, half-maximal inhibitory concentration: 3170 nM
For compound 4 the middle estimate is 1.7-fold (0.24 log units) above the measured one, within the range that was stated.
By their numbers in this assay, from the lowest: compounds 2, 4, 1 and 3 (each within the scatter of the next, the first and the last beyond it).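

On the ring carbon para to a large group, an exchange now gives a step beyond the scatter in this assay (a 2.2-fold lower number from compound 3 to compound 4 (0.34 log units; beyond the scatter)), which the exchange of nitro for methyl did not. Methoxy and nitro are not separated at this place (a 1.3-fold lower number from compound 1 to compound 4 (0.13 log units; within the scatter)), and 4-methoxyphenyl is not separated from 1H-benzimidazol-2-yl on the chain carbon bound to sulfur (a 1.8-fold higher number from compound 2 to compound 4 (0.25 log units; within the scatter)). No available evidence accounts for these results.

Open, on these data alone, is whether an amine, a carboxylic acid or a longer chain in place of methoxy at this ring carbon would give a step beyond the scatter.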